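The source may report more compounds than this note shows. Statements on the series, on what has been measured and on what is new or still open speak of the compounds shown alone.

In a functional assay on U-87MG ATCC cells for inhibition, with U-87 MG (Homo sapiens) as the target, read by MTT assay, with a stated time of 48 h (on this read-out lower numbers stand for stronger inhibition and higher numbers for weaker inhibition), three compounds on the shared core have been measured so far. Compound 1 `Fc1ccc(/C=N/Nc2nc(-c3ccc(C(F)(F)F)cc3)cs2)cc1F` gives 29900 nM, compound 2 `COc1ccccc1-c1csc(N/N=C/c2ccc(F)c(F)c2)n1` gives 40600 nM and compound 3 `Fc1ccc(/C=N/Nc2nc(-c3cccc(Br)c3)cs2)cc1F` gives 39900 nM. Compound 3 thus stands within the scatter of both others. Compound 4 `Fc1ccc(/C=N/Nc2nc(-c3ccccc3)cs2)cc1F` differs from compound 3 by hydrogen in place of bromo on an aromatic carbon. Among the compounds with values here, the one measured step that touches this ring, a 1.0-fold lower number from compound 2 to compound 3 (0.01 log units; within the scatter), stays within the scatter, although it is not the same change. No shift beyond the scatter is therefore expected in this assay. The expected result is a 1.1-fold lower number from compound 3 to compound 4 (0.02 log units; within the scatter). For compound 4 the estimate is 38000 nM, with an expected range of 17000 nM to 75000 nM.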

Compound 4, half-maximal inhibitory concentration: > 100000 nM
Compound 4 gave a limit, no number; the forecaster's own chance of this, stated with the estimate: 8%; middle value at least 2.6-fold (0.42 log units) away from the limit.
By their numbers in this assay, from the lowest: compounds 1, 3 and 2 (each within the scatter of the next). At a limit, above all of these: compound 4.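

In this assay the result for compound 4 is a limit and not a number: the limit of > 100000 nM in this assay, at which 1 of the 4 values shown sits. Hydrogen on this ring is the first change to move beyond the scatter, giving an at least 2.5-fold higher number from compound 3 to compound 4 (0.39 log units; beyond the scatter), an at least 2.4-fold higher number from compound 2 to compound 4 (0.39 log units; beyond the scatter) and an at least 3.3-fold higher number from compound 1 to compound 4 (0.52 log units; beyond the scatter). Bromo, methoxy and trifluoromethyl, though different groups at different places, stay within the scatter of one another, so having a group on this ring separates these compounds, not which of the three it is. Still open, on these data alone, is how far compound 4 really lies from the others. Also open, as far as these compounds go, is whether an amine or a carboxylic acid on this ring would behave like these three groups or like hydrogen.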